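This account rests on a few compounds, and the source may have more. Where it says the series, first, only, none or still open, it means among the compounds named here.

Compound 2 `O=C1Nc2ccc(S(=O)(=O)N3CCOCC3)cc2/C1=N/c1ccc(Br)cc1` stands second highest of the three numbers in hand in a functional assay on HCT-116 cells (Homo sapiens) for cytotoxicity, read by sulforhodamine B assay, with a stated time of 24 h (a higher number here means a weaker inhibitor, a lower number a stronger inhibitor), giving 15300 nM, though within the scatter of both neighbours: compound 1 `N#CCC(=O)N/N=C1\C(=O)Nc2ccc(S(=O)(=O)N3CCOCC3)cc21` gives 10300 nM and compound 3 `O=C1Nc2ccc(S(=O)(=O)N3CCOCC3)cc2/C1=N/c1ccc(O)cc1` gives 27300 nM. Compound 4 `O=C1Nc2ccc(S(=O)(=O)N3CCOCC3)cc2/C1=N/NS(=O)(=O)c1ccccc1` is not yet measured; it differs from compound 2 by (phenylsulfonyl)amino in place of 4-bromophenyl on a double-bonded nitrogen. The steps at this site are a 1.5-fold higher number from compound 1 to compound 2 (0.17 log units; within the scatter) and a 2.7-fold higher number from compound 1 to compound 3 (0.42 log units; beyond the scatter), both small; a 1.8-fold higher number from compound 2 to compound 3 (0.25 log units; within the scatter) lies on an aromatic carbon and bears less. Compound 4 returns to an amino-linked group on the double-bonded nitrogen, as in compound 1, so no step beyond the scatter is expected in this assay. Compound 4 is estimated at 12000 nM, range 5000 nM to 30000 nM, a step of a 1.3-fold lower number from compound 2 to compound 4 (0.11 log units; within the scatter).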

Compound 4, half-maximal inhibitory concentration: 13300 nM
Estimate against measurement, compound 4: 1.1-fold (0.04 log units) below; the measured number falls inside the stated range.
By their numbers in this assay, from the lowest: compounds 1, 4, 2 and 3 (each within the scatter of the next, the first and the last beyond it).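

In this assay, (phenylsulfonyl)amino on the double-bonded nitrogen gives no step beyond the scatter against 4-bromophenyl (a 1.2-fold lower number from compound 2 to compound 4 (0.06 log units; within the scatter)) or against the (cyanomethyl)carbonyl on the amine nitrogen (a 1.3-fold higher number from compound 1 to compound 4 (0.11 log units; within the scatter)). Only the change from 4-hydroxyphenyl gives a step beyond the scatter (a 2.1-fold lower number from compound 3 to compound 4 (0.31 log units; beyond the scatter)), and it is modest, so amino-linked and directly attached aryl groups do not separate here, with compound 2 going against any such split. On these data alone, whether an amine or a carboxylic acid on the phenyl ring of the phenylsulfonyl group would shift the number remains open. The compounds shown come with no evidence that accounts for these steps.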